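Swapping the Aryl Amide of Compound 1 for Methoxyacetamide

This account rests on a few compounds, and the source may have more. Where it says the series, first, only, none or still open, it means among the compounds named here.

Compound 1 `O=C(Nc1cc(Cl)cc(Cl)c1)c1cccc(Nc2ncc(F)c(Nc3ccc(F)cc3)n2)c1` is the starting point of this account. In a functional assay on KB cells (Homo sapiens) for antiproliferative activity, read by sulforhodamine B assay, with a stated time of 3 days (a lower number here means a stronger inhibitor of growth, a higher number a weaker inhibitor of growth), compound 1 gives 20100 nM, the highest of the two numbers reported in this series. Its nearest neighbour is compound 3 `COc1cc(NC(=O)c2cccc(Nc3ncc(F)c(Nc4ccc(F)cc4)n3)c2)cc(OC)c1`, which in this assay gives 15500 nM; the step of a 1.3-fold lower number from compound 1 to compound 3 (0.11 log units; within the scatter) is within the scatter. Compound 2 `O=C(Nc1ccc(C(F)(F)F)cc1)c1cccc(Nc2ncc(F)c(Nc3ccc(F)cc3)n2)c1` reaches only a limit of the assay, > 10000 nM, and so reports no number. Because of the limit of > 10000 nM in this assay, at which 1 of the 3 values shown sits, the steps a step that the limit leaves unreadable from compound 1 to compound 2 and a step that the limit leaves unreadable from compound 2 to compound 3 cannot be read.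

Compound 4 `COCC(=O)Nc1cccc(Nc2ncc(F)c(Nc3ccc(F)cc3)n2)c1` differs from compound 1 by ((methoxymethyl)carbonyl)amino in place of (3,5-dichlorophenyl)carbamoyl on an aromatic carbon. Within the data shown here, the measured steps all exchange one aromatic group for another on an amide-type nitrogen, and none of them removes the aryl amide altogether, so no measured step bears directly on this change; the only readable step, from compound 1 to compound 3, was within the scatter, and both measured numbers sit in the same weak region. On that basis a step of no more than the scatter is expected, in no fixed direction, and compound 4 is estimated to give 15000 nM in this assay, between 4000 nM and 60000 nM. That estimate means a step of a 1.3-fold lower number from compound 1 to compound 4 (0.13 log units; within the scatter) that is expected to stay within the usual spread.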

Compound 4, concentration for 50% growth inhibition: 6250 nM
Beside the measured number, compound 4's estimate is 2.4-fold (0.38 log units) above it, and the stated range covers the measured number.
By their numbers in this assay, from the lowest: compound 4; then compounds 3 and 1 (each within the scatter of the next).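

In this assay, among these compounds, exchanging (3,5-dichlorophenyl)carbamoyl for ((methoxymethyl)carbonyl)amino on this aromatic carbon gives a 3.2-fold lower number from compound 1 to compound 4 (0.51 log units; beyond the scatter), the first readable step to lie beyond the scatter. Among the compounds shown here, the earlier compounds changed only the aromatic group on the amide-type nitrogen, and their one readable step stayed within the scatter, so they could not show that this position responds to a change of the whole group. The result also shows that growth inhibition in this assay does not depend on an aromatic ring in this substituent, since the entering group has no ring and the modest step still runs towards a lower number, although nothing measured here gives a reason for that step.

From the compounds shown here alone, it stays open whether the step comes from losing the dichlorophenyl ring or from gaining the methoxymethyl chain, which a plain acetyl amide or a longer ether chain at the same place could help to separate. Going by these compounds, it is equally open how a free amine or a carboxylic acid on this aromatic carbon would compare.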